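The compounds below may be only part of what the source reports. "The series", "measured", "known", "first", "only" and "open" are said of these compounds alone.

Measured so far:
compound 1 `COc1cc(N(C)C(=O)c2cccc([N+](=O)[O-])c2)cc(OC)c1OC`, >= 125000 nM
compound 2 `COc1cc(NC(=O)Nc2ccccc2)cc(OC)c1OC`, "not determined" (no result reported)
compound 3 `COc1cc(N(C)C(=O)c2ccccc2)cc(OC)c1OC`, >= 125000 nM

In a functional assay on ONS-76 cells (Homo sapiens) for cytotoxicity, read by MTT assay, with a stated time of 72 h (a lower number here means a stronger inhibitor, a higher number a weaker inhibitor), compound 3 reaches only a limit of the assay, >= 125000 nM. Compound 1 likewise reaches only a limit, >= 125000 nM. For compound 2 no result is reported, "not determined" (no result reported). The change from compound 3 to compound 1 is nitro in place of hydrogen on an aromatic carbon; its step, a step that the two limits leave unreadable from compound 3 to compound 1, cannot be read, given (the limit of >= 125000 nM in this assay, at which 2 of the 3 values shown sit). Compound 4 `COc1cc(NC(=O)Nc2cccc([N+](=O)[O-])c2)cc(OC)c1OC` is not yet measured; it differs from compound 2 by nitro in place of hydrogen on an aromatic carbon, the same change as that from compound 3 to compound 1. The difference between the core of compound 2 and the core of compound 3 is not broken down here. In this assay the step from compound 2 to compound 4 is expected to be small, resting only on the unreadable step that the two limits leave unreadable from compound 3 to compound 1. Compound 4 is expected to give 100000 nM, estimated between 20000 nM and 250000 nM, and may itself end at a limit.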

Compound 4, half-maximal inhibitory concentration: 79600 nM
The estimate for compound 4 lay 1.3-fold (0.10 log units) above the measured number, within the range that was stated.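

No new step can be read: compound 4 has a number, but compound 2 carries no result to set against it. The compounds shown leave open the size of the nitro change on either core in this assay: the limit of >= 125000 nM in this assay, at which 2 of the 4 values shown sit.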